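This account rests on a few compounds, and the source may have more. Where it says the series, first, only, none or still open, it means among the compounds named here.

Measured so far:
compound 1, `O=c1[nH]c(=O)n([C@H]2C[C@@H]3O[PH](O)(O)OC[C@H]3O2)cc1Br`, in a functional assay on L1210 cells (Mus musculus) for antiproliferative activity (a lower number here means a stronger inhibitor, a higher number a weaker inhibitor), compound 1 gives 457 ug/mL.
compound 2, `O=c1[nH]c(=O)n([C@H]2C[C@H](O)[C@@H](COP(=O)(O)O)O2)cc1Br`, in this assay compound 2 gives 34.6 ug/mL.

Of the two measured compounds, compound 2 carries the lower number in this assay, and its gap to compound 1 lies beyond the usual scatter, so compound 2 is the stronger inhibitor of the pair. Compound 1 is the only other compound with a value, and its structure differs from compound 2 in more than one place, so the two numbers are shown side by side without a single counted step between them.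

Compound 3, `O=c1[nH]c(=O)n([C@H]2C[C@H](O)[C@@H](COP(=O)(O)O)O2)cc1C(F)(F)F`, is not yet measured in this assay. It departs from compound 2 in one place: trifluoromethyl in place of bromo on an aromatic carbon. Going by the values given here, no measured pair shows this exchange, so no step of known size is available to lean on. The account rests on the change alone. For compound 3 a step of a 5.8-fold lower number from compound 2 to compound 3 (0.76 log units; beyond the scatter) toward a lower number is expected, a shift of moderate size rather than one within the scatter. In this assay compound 3 is estimated at 6 ug/mL, with a range from 1.5 ug/mL to 25 ug/mL.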

Compound 3, concentration for 50% inhibition: 0.017 ug/mL
Compound 3: middle estimate off by 350-fold (2.55 log units), on the high side, and the stated range ends above it.
By their numbers in this assay, from the lowest: compound 3; then compound 2; then compound 1.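

In this assay, the exchange gives a 2000-fold lower number from compound 2 to compound 3 (3.31 log units; beyond the scatter), a large step and the first one here that can be read at a single place, since compound 1 and compound 2 differ in more than one place. It shows that this aromatic carbon of the six-membered aromatic ring with 2 nitrogen, two atoms from the ring nitrogen, is not indifferent to what it carries: with the rest of compound 2 unchanged, replacing the single bromine atom with the four heavy atoms of trifluoromethyl moves the number far beyond the scatter, although neither group brings a ring, a hydrogen-bond donor or acceptor, or a net charge. Nothing among the data shown accounts for the size of this step, so it stands as an observation without an explanation.

From the compounds shown here alone, with only bromo and trifluoromethyl compared at this position, it remains open whether a nitrile, an amine, a carboxylic acid or a longer chain there would move the number in the same direction. Going by these compounds, it also remains open whether the same exchange would produce a step of similar size on the core of compound 1.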